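This account rests on a few compounds, and the source may have more. Where it says the series, first, only, none or still open, it means among the compounds named here.

Working notes on the chalcone series in a functional assay on PC-3 cells (Homo sapiens), read by fluorescence and BrdU incorporation, with a stated time of 48 h, tested at 10 uM; on this read-out lower numbers stand for a stronger effect and higher numbers for a weaker effect at the one concentration tested.

Three members have been measured. Compound 1 `COc1cc(OC)c(C(=O)/C=C/c2ccccc2SC)c(OC)c1` gives 30% in this assay. Compound 2 `COc1cccc(/C=C/C(=O)c2c(OC)cc(OC)cc2OC)c1` gives 23% in this assay, and compound 3 `COc1cc(OC)c(C(=O)/C=C/c2ccccc2)c(OC)c1` gives 24% in this assay. Compound 3 holds the second highest of the three numbers; its nearest neighbour is compound 2, with a number 1 percentage points higher from compound 2 to compound 3 (within the scatter), and the furthest is compound 1, with a number 6 percentage points lower from compound 1 to compound 3 (within the scatter). The step of a number 7 percentage points lower from compound 1 to compound 2 (within the scatter) is also within the scatter, so the three measured compounds are not separable in this assay.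

The next member, compound 4 `COc1cc(OC)c(C(=O)/C=C/c2ccc(Cl)cc2)c(OC)c1`, differs from compound 3 in one place: chloro in place of hydrogen on an aromatic carbon

For the measured compounds named here, no measured step introduces a chloro group. Going by the values given here, the steps that bear on the change are those that alter a single group on the same ring, namely a number 6 percentage points lower from compound 1 to compound 3 (within the scatter) and a number 1 percentage points higher from compound 2 to compound 3 (within the scatter), and both stayed within the scatter. On that basis the expected step of no change at the digits printed from compound 3 to compound 4 (within the scatter) is not expected to exceed the scatter in either direction.

Compound 4 is therefore estimated at 24% in this assay, with the range 12% to 38%, pending measurement.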

Compound 4, a percentage reported as activity, at one concentration (the size of the read-out at that concentration, not a potency): 15%
The estimate for compound 4 lay 9 percentage points above the measured number; the measured number falls inside the stated range.
By their numbers in this assay, from the lowest: compounds 4, 2, 3 and 1 (each within the scatter of the next, the first and the last beyond it).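

In this assay, chloro in place of hydrogen on an aromatic carbon, para to a large group, gives a number 9 percentage points lower from compound 3 to compound 4 (within the scatter) and, with 4-chlorophenyl in place of 3-methoxyphenyl, the reading is a number 8 percentage points lower from compound 2 to compound 4 (within the scatter), so neither change separates the compounds involved. With 4-chlorophenyl in place of 2-(methylsulfanyl)phenyl, the step is a number 15 percentage points lower from compound 1 to compound 4 (beyond the scatter) and gives the series its first separated pair, though that step is modest and exchanges a whole substituted phenyl rather than a single group on an otherwise fixed ring. No supporting data bear on why this pair separates.

How much of that step belongs to the arrival of chloro and how much to the loss of methylsulfanyl stays unresolved, since the single-place step for chloro alone remains inside the scatter. Also open, going by these compounds, is how a bromo group, an amine or a carboxylic acid at the same place on the phenyl ring would read in this assay, and whether any such group would separate from the unsubstituted phenyl of the shared core.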